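From Fluoro to Bromo on Compound 2

The source may hold more compounds than are shown below. What is called first, only, known or untested is meant among the compounds shown, and "the series" means these compounds.

In a functional assay on CCRF-CEM cells (Homo sapiens) for inhibition (on this read-out lower numbers stand for stronger inhibition and higher numbers for weaker inhibition), three compounds have been measured so far. Compound 1 (`O=C1/C(=C/c2cccc(F)c2)CCc2ccccc21`) comes in at 8010 nM while compound 3 (`O=C1/C(=C/c2cccc(Br)c2)CCCc2ccccc21`) comes in at 8900 nM and compound 2 (`O=C1/C(=C/c2ccc(F)cc2)CCCc2ccccc21`) reaches 20000 nM as the highest number of the three. Compound 2 therefore shows the weakest inhibition of the set, and its distance to each of the other two lies beyond the scatter.

Compound 4 (`O=C1/C(=C/c2ccc(Br)cc2)CCCc2ccccc21`) differs from compound 2 in one place, with bromo in place of fluoro on an aromatic carbon, para to a large group (bromo in place of fluoro on an aromatic carbon). Within the data shown here, no two measured compounds differ in one place only, so no measured step shows this swap directly. Among the measured compounds shown here, on the same core as compound 2, compound 3 carries bromo at a different place on the ring, and its 8900 nM is the only guide, a thin one. A modest move towards a lower number is therefore expected. The expected step is a 2.0-fold lower number from compound 2 to compound 4 (0.30 log units; within the scatter) and would sit near the edge of the scatter. For compound 4 the estimated value is 10000 nM with an expected range of 4500 nM to 21000 nM on this reasoning.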

Compound 4, half-maximal inhibitory concentration: 17100 nM
Estimate against measurement, compound 4: 1.7-fold (0.23 log units) below; the range from low to high includes it.
By their numbers in this assay, from the lowest: compounds 1, 3, 4 and 2 (each within the scatter of the next, the first and the last beyond it).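

In this assay, among these compounds, the swap of fluoro for bromo on an aromatic carbon, para to a large group, can now be read directly for the first time: it gives a 1.2-fold lower number from compound 2 to compound 4 (0.07 log units; within the scatter), so at this position the two halogens cannot be told apart on this read-out. The earlier picture, in which compound 2 stood beyond the scatter of every other compound, therefore no longer holds, as compound 4 carries a different halogen at the same place and stays within the scatter of it. No measurement of any property of these compounds bears on this result, and the data offer no account of it.

Whether a group of another kind at this place, such as an amine, a carboxylic acid or a longer chain, would separate clearly from compound 2 remains open, as the compounds shown carry only fluoro and bromo here. Also open, on these data alone, is whether the same swap would give so small a step on the core of compound 1, or at the other ring position occupied in compound 3.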